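Amide in place of sulfonamide on the hydroxypropyl-derived side chain

The source may report more compounds than this note shows. Statements on the series, on what has been measured and on what is new or still open speak of the compounds shown alone.

Measured so far:
compound 1 `CCOc1cc(=O)n(CCCO)c2c1CC(CC=C(C)C)C(C)(C)C2` — 66.5%
compound 2 `CC(C)=CCC1Cc2c(OCCCNS(=O)(=O)c3ccc([N+](=O)[O-])cc3)cc(=O)n(CCCO)c2CC1(C)C` — 47.7%

In a functional assay on PANC-1 cells (Homo sapiens) for inhibition, read by MTT assay, with a stated time of 24 h, tested at 10 uM (on this read-out lower numbers stand for less inhibition and higher numbers for more inhibition at the one concentration tested (going by the name of the read-out)), compound 1 gives 66.5%. Compound 2 stands lowest of the two numbers; in this assay compound 2 gives 47.7%, a gap to compound 1 that lies beyond the usual scatter. Going by the values given here, no step between the two measured compounds is defined, so only the two values themselves are available.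

Compound 3 `COc1ccc(C(=O)NCCCOc2cc(=O)n(CCCO)c3c2CC(CC=C(C)C)C(C)(C)C3)cc1` is not yet measured. It differs from compound 2 as follows: (4-methoxyphenyl)carbonyl in place of (4-nitrophenyl)sulfonyl on an amine nitrogen. The change is confined to the group on the amine nitrogen of the side chain; the shared core and the remainder of the chain are unchanged.

No reference for this kind of exchange exists within the two measured compounds. The step from compound 2 to compound 3 is expected to be small, not clearly beyond the scatter, at a number 2.3 percentage points higher from compound 2 to compound 3 (within the scatter). For compound 3 the estimate in this assay is 50%, with a range from 30% to 70%.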

Compound 3, a percentage reported as inhibition, at one concentration (the size of the read-out at that concentration, not a potency): 55.5%
Beside the measured number, compound 3's estimate is 5.5 percentage points below it, and the stated range covers the measured number.
By their numbers in this assay, from the lowest: compounds 2 and 3 (each within the scatter of the next); then compound 1.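

In this assay the exchange of (4-nitrophenyl)sulfonyl for (4-methoxyphenyl)carbonyl on the amine nitrogen gives a number 7.8 percentage points higher from compound 2 to compound 3 (within the scatter) and so does not separate these two groups at this position. The first readable effect of the side chain itself is a number 11 percentage points lower from compound 1 to compound 3 (beyond the scatter) for (((4-methoxyphenyl)carbonyl)amino)methyl in place of hydrogen on a saturated chain carbon, a modest step. No accompanying measurement accounts for either step.

The exchange alters the linking group and the ring substituent together, so a (4-methoxyphenyl)sulfonyl group on the same nitrogen would be needed to tell the two apart. Also open, going by these compounds, is whether a free amine at the chain end, an acetyl group on the nitrogen or a longer chain would stay close to compound 3 or return toward compound 1.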